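A larger group on the nitrogen of compound 1

A few compounds are considered here, and "the series" means these few. Any claim that something is new, unique, unknown or untested is made for them only; others in the source may bear on it.

Three compounds have been measured in a functional assay on the whole organism (strain albino) for inhibition, with Rattus norvegicus as the target, read by paw edema, with stated times of 30 min and 1 h, at a dose of 100 mg/kg by the oral route; a higher number here means more inhibition at the dose given (going by the name of the read-out), a lower number less inhibition:

Compound 1 `Nc1ccc(C(=O)/C=C/c2ccco2)cc1` gives 33%
Compound 2 `COc1ccc(/C=C/C(=O)c2ccc(NC(=O)CBr)cc2)cc1` gives 37%
Compound 3 `CC(Br)C(=O)Nc1ccc(C(=O)/C=C/c2ccc(Cl)cc2)cc1` gives 39%

The number for compound 1 stands at the low end of the three, yet compound 2 and compound 3 both lie within the usual scatter of it, so the three numbers show no real separation. Compound 4 `CC(O[N+](=O)[O-])C(=O)Nc1ccc(C(=O)/C=C/c2ccco2)cc1` differs from compound 1 by a group of 8 heavy atoms (3 carbon, 1 nitrogen, 4 oxygen; no ring) in place of a hydrogen atom, on a nitrogen on an aromatic ring. Compound 2 and compound 3 also carry a group on that nitrogen, but each has a different ring at the far end of the chain as well, so no single step is shown for this change alone. The step of a number 5 percentage points higher from compound 1 to compound 4 (within the scatter) is expected to be small, not beyond the scatter. Compound 4 is estimated at 38%, within a range from 25% to 50%.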

Compound 4, a percentage reported as inhibition, in the whole organism at one dose (the size of the read-out at that dose, not a potency): 41%
The estimate for compound 4 lay 3 percentage points below the measured number; the measured number falls inside the stated range.
By their numbers in this assay, from the lowest: compounds 1, 2, 3 and 4 (each within the scatter of the next).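

In this assay, the change gives a number 8 percentage points higher from compound 1 to compound 4 (within the scatter) with the core of compound 1 held the same, the first view of this nitrogen on its own. A group of 8 heavy atoms can therefore stand in place of a hydrogen atom on this nitrogen, yet the two compounds cannot be told apart in this assay. Nothing at hand offers a reason for this result.

On these data alone, whether a simple acetyl group or a longer carbon chain on this nitrogen would give a number beyond the scatter of compound 1 remains open.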